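The source may hold more compounds than are shown below. What is called first, only, known or untested is meant among the compounds shown, and "the series" means these compounds.

Measured compounds in an assay on cells for inhibition of Indoleamine 2,3-dioxygenase 1 (Homo sapiens), read by HPLC, with a stated time of 20 min; on this read-out higher numbers stand for weaker inhibition and lower numbers for stronger inhibition:
- compound 1 `Nc1ccc(Cl)cc1-c1nnc[nH]1`: compound 1 gives 35 nM
- compound 2 `Nc1ccccc1-c1nnn[nH]1`: compound 2 gives 5800 nM

Compound 2 stands at the highest of the two numbers. Its nearest neighbour is compound 1, whose value is far lower, a gap well beyond the scatter; the two compounds differ in more than one place, so nothing can be read from that pair about any single change.

Compound 3 `Nc1ccc(Cl)cc1-c1nnn[nH]1` is not yet measured. It differs from compound 2 by chloro in place of hydrogen on an aromatic carbon. For the measured compounds named here, no measured pair isolates this change, so the size of the step rests only on the fact that compound 1, the one compound carrying chloro, sits far below compound 2. A drop beyond the scatter is expected, though not one that closes the whole gap to compound 1.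

For compound 3 in this assay an estimate of 1500 nM is made, within 300 nM to 7000 nM, meaning an expected step of a 3.9-fold lower number from compound 2 to compound 3 (0.59 log units; beyond the scatter).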

Compound 3, half-maximal inhibitory concentration: 220 nM
Beside the measured number, compound 3's estimate is 6.8-fold (0.83 log units) above it, and the stated range ends above it.
By their numbers in this assay, from the lowest: compound 1; then compound 3; then compound 2.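

In this assay the series now has its first comparison that differs in one place, and it gives a 26-fold lower number from compound 2 to compound 3 (1.42 log units; beyond the scatter) on placing chloro in place of hydrogen on the aromatic carbon para to the amino group. Chloro at this position therefore carries a large step on its own, which compound 1 could not show, since it differs from compound 2 in more than one place. No measurement at hand accounts for the size of this step.

From the compounds shown here alone, whether the step belongs to chloro alone stays open, and fluoro, bromo, methyl or methoxy on the same carbon would settle that. Also open, going by these compounds, is whether chloro has a similar effect on the other carbons of the six-membered aromatic ring, and whether it persists when a hydroxyl or methylamino group replaces the amino group.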